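This account rests on a few compounds, and the source may have more. Where it says the series, first, only, none or still open, it means among the compounds named here.

Measured so far in a functional assay on PC-12 cells (Rattus norvegicus) for cytotoxicity, read by MTT assay, with stated times of 3 h and 2 h, tested at 0.1 uM; a lower number here means a weaker effect, a higher number a stronger effect of the compound at the concentration tested:

compound 1, `Cc1cc(=O)oc2cc(OCCCn3cc(CNC(=O)CCCCC4CCSS4)nn3)ccc12`: 44.8%
compound 2, `O=C(CCCCC1CCSS1)NCc1cn(CCCOc2ccc3cc(C(=O)O)c(=O)oc3c2)nn1`: 43.4%

In this assay compound 1 gives 44.8% and compound 2 gives 43.4%. The two numbers lie within the usual scatter of each other, so compound 2 stands level with compound 1 and no order can be set between them.

Compound 3, `O=C(CCCCC1CCSS1)NCc1cn(CCCOc2ccc3cc(-c4ccc(Cl)cc4)c(=O)oc3c2)nn1`, has not yet been measured in this assay. It differs from compound 2 in one place: 4-chlorophenyl in place of carboxy on an aromatic carbon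

For the measured compounds named here, no step between measured compounds is available to set a size for such an exchange on the shared core. Going by the values given here, the only comparison at hand, compound 1 against compound 2, shows two values within the scatter. On that basis no step beyond the scatter is expected from compound 2 to compound 3, and the expected step is a number 1.6 percentage points higher from compound 2 to compound 3 (within the scatter). Compound 3 is estimated at 45%, with a range from 30% to 60%.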

Compound 3, a percentage reported as activity, at one concentration (the size of the read-out at that concentration, not a potency): 40.9%
The estimate for compound 3 lay 4.1 percentage points above the measured number; low and high end bracket the measured number.
By their numbers in this assay, from the lowest: compounds 3, 2 and 1 (each within the scatter of the next).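

In this assay, 4-chlorophenyl in place of carboxy on this aromatic carbon gives a number 2.5 percentage points lower from compound 2 to compound 3 (within the scatter), so in this pair the position takes a substantial exchange of groups without a step that can be told from the scatter. The group that leaves has no ring and carries 1 hydrogen-bond donor and 1 hydrogen-bond acceptor, while the group that enters brings a six-membered aromatic ring of carbon only with 0 hydrogen-bond donors and 0 hydrogen-bond acceptors, and this one pair shows no readable step with that exchange. No measurement at hand bears on this result.

Going by these compounds, whether an amine or a methyl ester on the same aromatic carbon would give a step beyond the scatter stays open. A read-out at a single concentration also leaves open how the compounds compare at other concentrations.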